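Benzyl ring substituent change from trifluoromethyl to nitro

The source may report more compounds than this note shows. Statements on the series, on what has been measured and on what is new or still open speak of the compounds shown alone.

Measured so far:
compound 1, `COc1ccc(Cn2c(NCCNC(=N)N)nc(=O)n(Cc3ccc(C)cc3)c2=O)cc1`, in a functional assay on the whole organism (strain C57Bl/6) for inhibition, with Mus musculus as the target, with a stated time of 180 min, at 48 degrees C (on this read-out higher numbers stand for an effect only at larger amounts of compound and lower numbers for an effect already at smaller amounts), compound 1 gives 0.0044 nM
compound 2, `COc1ccc(Cn2c(NCCNC(=N)N)nc(=O)n(Cc3ccc(C(F)(F)F)cc3)c2=O)cc1`, in this assay compound 2 gives 0.051 nM

Among the compounds with values here, compound 2 holds the highest of the two numbers so far; its nearest neighbour is compound 1, and the one measured step, a 12-fold higher number from compound 1 to compound 2 (1.06 log units; beyond the scatter), separates them. That step is the only one in hand, and it concerns a change on the same aromatic carbon as the one now considered.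

Compound 3, `COc1ccc(Cn2c(NCCNC(=N)N)nc(=O)n(Cc3ccc([N+](=O)[O-])cc3)c2=O)cc1`, is not yet measured. It differs from compound 2 by nitro in place of trifluoromethyl on an aromatic carbon.

Within the data shown here, no measured step covers nitro directly. Among the measured compounds shown here, the single step from methyl to trifluoromethyl shows that a change at this aromatic carbon can move the number well beyond the scatter, but it gives no direction for the present change. With trifluoromethyl and nitro both without hydrogen-bond donors and of similar size, the estimate for compound 3 is kept near compound 2, expected as a 1.0-fold lower number from compound 2 to compound 3 (0.01 log units; within the scatter), with a wide range. Compound 3 is therefore expected to give about 0.05 nM in this assay, between 0.01 nM and 0.3 nM.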

Compound 3, half-maximal effective concentration: 0.048 nM
Compound 3: the middle estimate sits 1.0-fold (0.02 log units) above what was measured; measured number inside the range.
By their numbers in this assay, from the lowest: compound 1; then compounds 3 and 2 (each within the scatter of the next).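

In this assay nitro in place of trifluoromethyl gives a 1.1-fold lower number from compound 2 to compound 3 (0.03 log units; within the scatter) and so leaves the number within the scatter, even though the two groups differ in their atoms and in their count of hydrogen-bond acceptors. Methyl can now be compared with two groups instead of one: an 11-fold higher number from compound 1 to compound 3 (1.04 log units; beyond the scatter) stands alongside a 12-fold higher number from compound 1 to compound 2 (1.06 log units; beyond the scatter) and shows that the large gap from methyl is not particular to trifluoromethyl, with compound 1 holding the lowest number of the three and both of its steps lying beyond the scatter. No measurement is at hand that accounts for the match between nitro and trifluoromethyl or for the gap from methyl.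

Whether the low number belongs to methyl alone stays open, since the compounds shown carry no ethyl, methoxy, amine or carboxylic acid on this aromatic carbon and no plain hydrogen there. Going by these compounds, it also stays open whether the same order among methyl, trifluoromethyl and nitro would hold if the methoxy group on the other benzyl were replaced, for instance by chlorine.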